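Thiophen-3-yl in Place of 4-Nitrophenyl on the Chain

The source may report more compounds than this note shows. Statements on the series, on what has been measured and on what is new or still open speak of the compounds shown alone.

Measured compounds:
- compound 1, `COc1cccc(/C=C/C(=O)c2ccc(OC)c3c2OC(C)(C)C=C3)c1`: > 10000 nM
- compound 2, `COc1ccc(C(=O)/C=C/c2ccc(F)cc2)c2c1C=CC(C)(C)O2`: > 10000 nM
- compound 3, `COc1ccc(C(=O)/C=C/c2ccc([N+](=O)[O-])cc2)c2c1C=CC(C)(C)O2`: 3730 nM

In a functional assay on HT-29 cells (Homo sapiens) for antiproliferative activity, read by MTT assay, with a stated time of 24 h (a higher number here means a weaker inhibitor, a lower number a stronger inhibitor), compound 1 gives > 10000 nM, which is a limit of the assay and not a number. Compound 2 likewise gives > 10000 nM, again a limit. For the measured compounds named here, compound 3 gives 3730 nM, the only number among the three. The two steps that lead to it are an at least 2.6-fold lower number from compound 1 to compound 3 (0.42 log units; beyond the scatter) and an at least 2.6-fold lower number from compound 2 to compound 3 (0.42 log units; beyond the scatter), and the step that the two limits leave unreadable from compound 1 to compound 2 cannot be sized because of the limit of > 10000 nM in this assay, at which 2 of the 3 values shown sit.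

Compound 4, `COc1ccc(C(=O)/C=C/c2ccsc2)c2c1C=CC(C)(C)O2`, differs from compound 3 in one place: thiophen-3-yl in place of 4-nitrophenyl on a double-bonded chain carbon bound to a double-bonded chain carbon. Going by the values given here, the steps that bear on this change are the two into compound 3, where only the 4-nitrophenyl group yielded a number while the 3-methoxyphenyl and 4-fluorophenyl groups sat at the limit. Among the compounds with values here, replacing the 4-nitrophenyl with thiophen-3-yl removes the one group that gave a readable value, so compound 4 is expected to return toward the limit, with the step of a 2.7-fold higher number from compound 3 to compound 4 (0.43 log units; beyond the scatter) expected to raise the number. Compound 4 is therefore estimated at 10000 nM, between 4000 nM and 30000 nM.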

Compound 4, half-maximal inhibitory concentration: > 10000 nM
Compound 4 was reported as a limit (the forecaster's own chance of this, stated with the estimate: 55%); the middle value lies on the limit itself.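

For the compounds shown here, putting the thiophen-3-yl group in place of 4-nitrophenyl on this double-bonded chain carbon gives an at least 2.6-fold higher number from compound 3 to compound 4 (0.42 log units; beyond the scatter) in this assay, so the one readable value in the set is not kept. The earlier compounds shown here tested only substituted phenyl groups at this place, whereas compound 4 shows that a five-membered aromatic ring with one hetero atom also fails to give a readable value here, which leaves compound 3 alone with a number among the four. The steps from compound 1 and from compound 2 to compound 4 cannot be read, and no order can be given among these three compounds, for a single reason: the limit of > 10000 nM in this assay, at which 3 of the 4 values shown sit.

With only one readable value, the compounds shown cannot tell whether the nitro group itself carries the gain or whether other groups on the same phenyl ring would do as well. Going by these compounds, it remains open what a 4-aminophenyl or a 4-carboxyphenyl group would give at this place, and whether either would bring a readable number in this assay at all.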